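A few compounds are considered here, and "the series" means these few. Any claim that something is new, unique, unknown or untested is made for them only; others in the source may bear on it.

Measured compounds in an assay on FRT-Jurkat cells for inhibition of nuclear factor NF-kappa-B complex (Homo sapiens), read by flow cytometry, with a stated time of 24 h, tested at 10 uM; on this read-out higher numbers stand for more inhibition at the one concentration tested (going by the name of the read-out) and lower numbers for less inhibition:
- compound 1, `COc1ccc(Nc2cccc3c2C(=O)N(C2CCC(=O)NC2=O)C3=O)cc1`: 13%
- compound 2, `O=C1CCC(N2C(=O)c3ccc(Nc4ccc(O)cc4)cc3C2=O)C(=O)N1`: 4%
- compound 3, `CC(C)(C)c1ccc(Nc2ccc3c(c2)C(=O)N(C2CCC(=O)NC2=O)C3=O)cc1`: 17%

On these three numbers compound 1 is not separated from either neighbour: its gap to compound 3 and its gap to compound 2 both lie within the scatter, so the three compounds cannot be ranked against one another from this read-out alone. Going by the values given here, only one step among them exceeds the scatter, a number 13 percentage points higher from compound 2 to compound 3 (beyond the scatter), with tert-butyl in place of hydroxy on an aromatic carbon.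

Compound 4, `CCCCCc1ccc(Nc2cccc3c2C(=O)N(C2CCC(=O)NC2=O)C3=O)cc1`, is still to be measured. It differs from compound 1 by pentyl in place of methoxy on an aromatic carbon. The one comparable move, a number 13 percentage points higher from compound 2 to compound 3 (beyond the scatter), also swaps an oxygen-bearing substituent for a branched carbon chain on the same aromatic ring, though the shared core carries its amine at a different ring carbon in that pair. Taken as the only guide, a modest upward step is expected for compound 4, a number 7 percentage points higher from compound 1 to compound 4 (within the scatter), with no strong reason to expect a change beyond the scatter. The expected value for compound 4 is 20%, with a range from 5% to 38%.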

Compound 4, a percentage reported as inhibition, at one concentration (the size of the read-out at that concentration, not a potency): 23%
For compound 4 the middle estimate is 3 percentage points below the measured one; measured number inside the range.
By their numbers in this assay, from the lowest: compounds 2, 1, 3 and 4 (each within the scatter of the next, the first and the last beyond it).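

In this assay, pentyl in place of methoxy, on an aromatic carbon para to a large group, gives a number 10 percentage points higher from compound 1 to compound 4 (within the scatter), so this exchange of an oxygen-bearing group for a longer all-carbon chain is not separated from no change at this position. Going by these compounds alone, this is the first step read on the core of compound 1 itself, whereas a number 13 percentage points higher from compound 2 to compound 3 (beyond the scatter), the only step beyond the scatter, belongs to a core carrying its amine at a different ring carbon and to another pair of groups. Nothing available explains the size of this step.

From the compounds shown here alone, whether a longer chain, an amine or a carboxylic acid at this carbon would give a step beyond the scatter remains open. Also open, going by these compounds, is whether pentyl would give a similar step on the core of compound 3.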